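Moving one chloro on the ring of compound 3

The compounds below may be only part of what the source reports. "The series", "measured", "known", "first", "only" and "open" are said of these compounds alone.

Compound 1 `O=C(O)c1ccc(C(=O)/C(=C\c2ccc(F)c([N+](=O)[O-])c2)SCc2ccc(Cl)cc2Cl)cc1`: 1000 nM
Compound 2 `O=C(O)c1ccc(C(=O)/C(=C\c2ccc(F)c([N+](=O)[O-])c2)SCc2ccc(C(F)(F)F)cc2)cc1`: 1000 nM
Compound 3 `O=C(O)c1ccc(C(=O)/C(=C\c2ccc(F)c([N+](=O)[O-])c2)SCc2ccc(Cl)cc2)cc1`: 50000 nM

These three compounds were tested in a functional assay on DU-145 cells (Homo sapiens) for inhibition, read by trypan blue exclusion, with a stated time of 96 h (a higher number here means a weaker inhibitor of growth, a lower number a stronger inhibitor of growth), and they differ only in the group on a saturated chain carbon bound to a sulfur. Compound 3 has the highest number, which makes it the weakest growth inhibitor of the three. Compound 1 and compound 2 cannot be told apart: no change at the digits printed from compound 1 to compound 2 (within the scatter).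

Compound 4 `O=C(O)c1ccc(C(=O)/C(=C\c2ccc(F)c([N+](=O)[O-])c2)SCc2ccccc2Cl)cc1` holds the same atoms as compound 3, joined differently: 2-chlorophenyl in place of 4-chlorophenyl on a saturated chain carbon bound to a sulfur. In words, 2-chlorophenyl stands in place of 4-chlorophenyl.

Among the measured compounds shown here, no measured step makes this exact move. The closest evidence is a 50-fold higher number from compound 1 to compound 3 (1.70 log units; beyond the scatter), a large step that replaces the 2,4-dichlorophenyl group with 4-chlorophenyl. For the measured compounds named here, compound 4 keeps the chloro that compound 3 lacks, but it loses the one that compound 3 retains, and no measured compound carries 2-chlorophenyl. Some of that large step may therefore be regained, though probably not all of it.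

The expected change is an 8.3-fold lower number from compound 3 to compound 4 (0.92 log units; beyond the scatter). For compound 4 the estimated value is 6000 nM, with an expected range of 1000 nM to 50000 nM.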

Compound 4, concentration for 50% growth inhibition in the DU-145 assay: 1000 nM
Compound 4: the middle estimate sits 6.0-fold (0.78 log units) above what was measured; the measured number falls inside the stated range.
By their numbers in the DU-145 assay, from the lowest: compounds 1, 2 and 4 (each within the scatter of the next); then compound 3.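

In the DU-145 assay, moving the single chloro gives a 50-fold lower number from compound 3 to compound 4 (1.70 log units; beyond the scatter), so on this ring where the chloro sits matters, not only that it is there. The 2,4-dichlorophenyl group of compound 1 and the 2-chlorophenyl group of compound 4 then read alike, with no change at the digits printed from compound 1 to compound 4 (within the scatter) for hydrogen in place of a chloro, which suggests that among the chloro compounds shown, the chloro that compound 3 lacks is the one that counts. Compound 2 goes against any rule that this chloro is needed, since no change at the digits printed from compound 2 to compound 4 (within the scatter) shows that 4-(trifluoromethyl)phenyl, which has no chloro at all, cannot be told apart from 2-chlorophenyl.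

As far as these compounds go, how a plain phenyl or a methoxyphenyl group would behave on the saturated chain carbon bound to a sulfur stays open, as does whether anything can go beyond the level shared by compounds 1, 2 and 4. In a physicochemical assay for solubility (on this read-out higher numbers stand for higher solubility and lower numbers for lower solubility), compound 3 gives < 1000 ug/mL, which is a limit of the assay and not a number. In the physicochemical assay compound 4 gives < 1000 ug/mL, which is likewise a limit of the assay and not a number. In the physicochemical assay the step from compound 3 to compound 4 cannot be read, so nothing can be said about whether moving the chloro changes solubility: the limit of < 1000 ug/mL in the physicochemical assay, at which 2 of the 2 values shown sit.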